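A pyridin-2-yl in place of 4-chlorophenyl

This account rests on a few compounds, and the source may have more. Where it says the series, first, only, none or still open, it means among the compounds named here.

In a functional assay on MDA-MB-435 cells (Homo sapiens) for cytotoxicity, read by MTT assay, with a stated time of 72 h (a higher number here means a weaker inhibitor, a lower number a stronger inhibitor), compound 3 `N[C@H]1CC[C@H](Nc2c(C(=O)NCc3ccc(Cl)cc3)nc(Br)c3cccnc23)CC1` gives 1000 nM, the lowest of the three numbers. Compound 2 `N[C@H]1CC[C@H](Nc2c(C(=O)NCc3ccc(F)cc3)nc(Br)c3cccnc23)CC1` gives 6000 nM and compound 1 `COc1cccc(CNC(=O)c2nc(Br)c3cccnc3c2N[C@H]2CC[C@H](N)CC2)c1` gives 7000 nM, with a 1.2-fold lower number from compound 1 to compound 2 (0.07 log units; within the scatter). Compound 4 `N[C@H]1CC[C@H](Nc2c(C(=O)NCc3ccccn3)nc(Br)c3cccnc23)CC1` carries pyridin-2-yl in place of 4-chlorophenyl on a saturated chain carbon bound to an amide-type nitrogen. For the measured compounds named here, two measured steps bear on this change: a 6.0-fold lower number from compound 2 to compound 3 (0.78 log units; beyond the scatter), with chloro in place of fluoro on an aromatic carbon, and a 7.0-fold lower number from compound 1 to compound 3 (0.85 log units; beyond the scatter). Both are modest. Going by the values given here, only compound 3 carries 4-chlorophenyl, and no measured compound carries pyridin-2-yl, so the evidence is indirect. A modest move to a higher number is therefore expected, a 5.0-fold higher number from compound 3 to compound 4 (0.70 log units; beyond the scatter). The estimate for compound 4 is 5000 nM, with an expected range of 1500 nM to 15000 nM.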

Compound 4, half-maximal inhibitory concentration: 4000 nM
The estimate for compound 4 lay 1.3-fold (0.10 log units) above the measured number; the measured number falls inside the stated range.
By their numbers in this assay, from the lowest: compound 3; then compounds 4, 2 and 1 (each within the scatter of the next).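

At this place, on a saturated chain carbon bound to an amide-type nitrogen, pyridin-2-yl does not keep the lower number seen with 4-chlorophenyl (a 4.0-fold higher number from compound 3 to compound 4 (0.60 log units; beyond the scatter)). Against the other two groups, pyridin-2-yl stays within the scatter (a 1.5-fold lower number from compound 2 to compound 4 (0.18 log units; within the scatter); a 1.8-fold lower number from compound 1 to compound 4 (0.24 log units; within the scatter)). Among these four compounds, only the 4-chlorophenyl of compound 3 stands apart in this assay. The compounds shown leave open whether 4-bromophenyl or pyridin-3-yl in the same place would match 4-chlorophenyl or pyridin-2-yl. Nothing measured here explains the difference between these groups.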